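Second chloro on the fused ring: compound 2 to compound 3

This account rests on a few compounds, and the source may have more. Where it says the series, first, only, none or still open, it means among the compounds named here.

Compound 1 `O=c1oc(-c2ccccc2I)nc2cccc(Cl)c12` and compound 2 `O=c1oc(-c2ccccc2I)nc2ccc(Cl)cc12` differ only in where the chloro sits on the shared core. In an assay on isolated protein for inhibition of complement C1r subcomponent (Homo sapiens) (on this read-out lower numbers stand for stronger inhibition and higher numbers for weaker inhibition), compound 1 gives 13500 nM, and in this assay compound 2 gives 7800 nM. Compound 2 carries the lower of the two numbers, yet the gap to compound 1 stays inside the usual scatter, so neither can be called the stronger inhibitor.

Compound 3 `O=c1oc(-c2ccccc2I)nc2cc(Cl)c(Cl)cc12` keeps the iodophenyl group and the core of compound 2, with one change: chloro in place of hydrogen on an aromatic carbon. Among the compounds with values here, no matched step of this kind has been measured in the set, so the size of the effect is unknown. The expectation is a modest step, if any, towards a lower number, not clearly beyond the scatter.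

For compound 3 the estimated value is 5500 nM, with an expected range from 2500 nM to 12000 nM. The implied step a 1.4-fold lower number from compound 2 to compound 3 (0.15 log units; within the scatter) is thus expected to be small.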

Compound 3, half-maximal inhibitory concentration: > 62500 nM
Compound 3 was reported as a limit; the forecaster's own chance of this, stated with the estimate: 5%; at least 11-fold (1.05 log units) between middle value and limit.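

Chloro in place of hydrogen on an aromatic carbon, ortho to a chloro group, gives an at least 8.0-fold higher number from compound 2 to compound 3 (0.90 log units; beyond the scatter), the first step in the series that lies beyond the scatter in this assay. For compound 3 the reading is a limit of the assay, not a number: the limit of > 62500 nM in this assay, at which 1 of the 3 values shown sits.

Compound 1 and compound 2, each with one chloro on the shared core, stand within the scatter of each other, so only this second chloro shows that the read-out can respond to a change on this ring.

Open, on these data alone, is whether the step belongs to chloro as such or to any group on this carbon; a fluoro or a methyl group there would separate the two. Also open, as far as these compounds go, is whether chloro on this carbon gives the same step when hydrogen replaces the chloro of compound 2.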